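Adding a Benzyl Group to a Piperidine Sigma Ligand

The compounds below may be only part of what the source reports. "The series", "measured", "known", "first", "only" and "open" are said of these compounds alone.

Compound 1 `COc1ccc(/C(C)=C/CN2CCC(Cc3ccccc3)CC2)cc1`: 4.14 nM
Compound 2 `COc1cccc(/C(C)=C/CN2CCCCC2)c1`: 91 nM

In an assay on cell membranes for displacement of a labelled ligand from Sigma non-opioid intracellular receptor 1 (Cavia porcellus), read by scintillation counting, with a stated time of 150 min (on this read-out higher numbers stand for weaker inhibition and lower numbers for stronger inhibition), compound 2 gives 91 nM, the highest number of the two measured compounds and thus the weaker inhibitor of the pair. Compound 1 gives 4.14 nM in this assay, a gap beyond the usual scatter.

Compound 3 `COc1cccc(/C(C)=C/CN2CCC(Cc3ccccc3)CC2)c1` differs from compound 2 in one place: benzyl in place of hydrogen on a saturated ring carbon. Among the compounds with values here, compound 1 also carries a benzyl group on its saturated ring, but it differs from compound 2 in a second place as well, so no measured pair isolates the benzyl change on its own. Within the data shown here, the comparison still points in one direction: the compound carrying the benzyl group is the one with the lower number. The step from compound 2 to compound 3 is therefore expected to lower the inhibition constant, beyond the scatter, by about a 9.1-fold lower number from compound 2 to compound 3 (0.96 log units; beyond the scatter). Compound 3 is estimated at 10 nM, with a likely range from 3 nM to 40 nM.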

Compound 3, inhibition constant: 7.7 nM
Compound 3: middle estimate off by 1.3-fold (0.11 log units), on the high side, within the range that was stated.
By their numbers in this assay, from the lowest: compounds 1 and 3 (each within the scatter of the next); then compound 2.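

With everything else held the same, benzyl in place of hydrogen on a saturated ring carbon now has its own measured effect in this assay, a large step: a 12-fold lower number from compound 2 to compound 3 (1.07 log units; beyond the scatter). This shows that the ring position three ring bonds from the ring nitrogen matters on its own, which could not be read from compound 1 and compound 2, as they differ in two places. With the benzyl group present, the two methoxyphenyl arrangements cannot be told apart, since 3-methoxyphenyl in place of 4-methoxyphenyl gives a 1.9-fold higher number from compound 1 to compound 3 (0.27 log units; within the scatter), a step within the scatter.

Nothing measured here speaks to the reason for the benzyl step. From the compounds shown here alone, whether a plain methyl group or a phenylethyl group, with its longer chain, would do the same at this ring carbon remains open.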